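This account rests on a few compounds, and the source may have more. Where it says the series, first, only, none or still open, it means among the compounds named here.

Compound 2 `Oc1n[nH]c(CN[C@H](COCc2cc(C(F)(F)F)cc(C(F)(F)F)c2)c2ccccc2)n1` gives 2.4 nM in an assay on CHO cells for displacement of a labelled ligand from Substance-P receptor (Homo sapiens); on this read-out higher numbers stand for weaker inhibition and lower numbers for stronger inhibition; among the three measured compounds its number is the second highest, lying within the scatter of compound 1 `CN(Cc1nc[nH]n1)[C@H](COCc1cc(C(F)(F)F)cc(C(F)(F)F)c1)c1ccccc1`, which gives 1.4 nM, and well apart from compound 3 `CN(Cc1nn[nH]n1)[C@H](COCc1cc(C(F)(F)F)cc(C(F)(F)F)c1)c1ccccc1`, which gives 70 nM. Compound 4 `CN(Cc1nnn(C)n1)[C@H](COCc1cc(C(F)(F)F)cc(C(F)(F)F)c1)c1ccccc1` differs from compound 2 by methyl((2-methyl-2H-tetrazol-5-yl)methyl)amino in place of ((3-hydroxy-1H-1,2,4-triazol-5-yl)methyl)amino on a saturated chain carbon bound to an aromatic carbon and a saturated chain carbon. Among the compounds with values here, two measured steps bear on this change: a 29-fold higher number from compound 2 to compound 3 (1.46 log units; beyond the scatter) and a 50-fold higher number from compound 1 to compound 3 (1.70 log units; beyond the scatter), both large weakenings when a 2H-tetrazol-5-yl ring enters. Within the data shown here, compound 4 carries instead a 2-methyl-2H-tetrazol-5-yl ring, which no measured compound has, so a weakening beyond the scatter is expected, though probably smaller than the step to compound 3. The expected step is a 13-fold higher number from compound 2 to compound 4 (1.10 log units; beyond the scatter). Compound 4 is therefore estimated at 30 nM, with a likely range from 8 nM to 120 nM.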

Compound 4, half-maximal inhibitory concentration: 16 nM
The estimate for compound 4 lay 1.9-fold (0.27 log units) above the measured number; measured number inside the range.
By their numbers in this assay, from the lowest: compounds 1 and 2 (each within the scatter of the next); then compound 4; then compound 3.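

Adding a methyl on the aromatic nitrogen of the tetrazole recovers part of the loss seen with the unsubstituted ring in this assay (a 4.4-fold lower number from compound 3 to compound 4 (0.64 log units; beyond the scatter)). The recovery is only partial, as the methylated ring still falls short of both triazoles (an 11-fold higher number from compound 1 to compound 4 (1.06 log units; beyond the scatter); a 6.7-fold higher number from compound 2 to compound 4 (0.82 log units; beyond the scatter)). Nothing available explains why these numbers shift.

From the compounds shown here alone, it remains open whether an ethyl group or a longer chain on that nitrogen would move the number further. Also unresolved is how either tetrazole would behave with hydrogen in place of the methyl on the amine nitrogen.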